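From compound 2 to compound 3: a methyl for a bromine

The source may report more compounds than this note shows. Statements on the series, on what has been measured and on what is new or still open speak of the compounds shown alone.

Measured compounds:
compound 1, `COC(=O)c1c(Br)cc(Br)cc1OC(=O)COc1cc(O)c2c(=O)cc(-c3ccccc3)oc2c1`, 398000 nM
compound 2, `COC(=O)c1c(Br)cccc1OC(=O)COc1cc(O)c2c(=O)cc(-c3ccccc3)oc2c1`, 388000 nM

In an ADME assay on cells (T-cell, Mus musculus, strain BALB/c) for cytotoxicity, read by MTT assay, with a stated time of 48 h (a lower number here means that less compound is tolerated, a higher number that more compound is tolerated), compound 2 gives the lowest of the two numbers, and its nearest neighbour is compound 1, which differs only in that a 1.0-fold lower number from compound 1 to compound 2 (0.01 log units; within the scatter). The two values therefore cannot be told apart.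

Compound 3, `COC(=O)c1cc(C)ccc1OC(=O)COc1cc(O)c2c(=O)cc(-c3ccccc3)oc2c1`, has not yet been measured in this assay. It differs from compound 2 as follows: a group of 11 heavy atoms (9 carbon, 2 oxygen; one six-membered aromatic ring of carbon only) in place of a group of 11 heavy atoms (8 carbon, 2 oxygen, 1 bromine; one six-membered aromatic ring of carbon only), on an oxygen next to a carbonyl group. Going by the values given here, the one measured step, a 1.0-fold lower number from compound 1 to compound 2 (0.01 log units; within the scatter), also touches a bromo on an aromatic carbon and stayed within the scatter; nothing else is known about the entering group. On that basis compound 3 is expected to show no step beyond the scatter, so that a 1.0-fold higher number from compound 2 to compound 3 (0.00 log units; within the scatter) is the estimated change. Compound 3 is thus estimated at 390000 nM, with a range from 200000 nM to 780000 nM.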

Compound 3, half-maximal cytotoxic concentration: 306000 nM
Estimate against measurement, compound 3: 1.3-fold (0.11 log units) above; measured number inside the range.
By their numbers in this assay, from the lowest: compounds 3, 2 and 1 (each within the scatter of the next).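

In this assay the replacement of the group on an oxygen next to a carbonyl group gives a 1.3-fold lower number from compound 2 to compound 3 (0.10 log units; within the scatter) and stays within the scatter. The earlier pair removed only one of two bromines, whereas compound 3 carries no bromine at all and has one more carbon in this group, yet it still cannot be told apart from compound 2. No available evidence bears on this result.

All three compounds lie within the scatter of their neighbours in the order of numbers, so no change shown here marks a limit on what this group tolerates. As far as these compounds go, whether an amine or a carboxylic acid on the six-membered aromatic ring of this group, or a longer chain there, would move the number beyond the scatter stays open.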